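A Benzyl Group Added to the Core of Compound 1

The source may hold more compounds than are shown below. What is called first, only, known or untested is meant among the compounds shown, and "the series" means these compounds.

Compounds measured in an assay on isolated protein for inhibition of N-lysine methyltransferase SMYD2 (Homo sapiens), read by filter binding, with a stated time of 1 h; a lower number here means a stronger inhibitor, a higher number a weaker inhibitor:
compound 1 `CN1C(=O)C(CCNc2ccccc2)COC12C=CC(=O)C=C2` gives > 20000 nM, which is a limit of the assay.
compound 2 `CN1C(=O)C(CCNc2ccc(Cl)c(Cl)c2)COC12C=CC(=O)C=C2` gives 3820 nM.
compound 3 `CN1C(=O)C(CCNc2ccc(C(=O)c3ccccc3)cc2)COC12C=CC(=O)C=C2` gives > 20000 nM, again a limit of the assay.

Compound 1 therefore sits at the limit of > 20000 nM in this assay, at which 2 of the 3 values shown sit, and only compound 2 gives a number in this assay. The unmeasured compound 4 `CN1C(=O)C(CCNc2cccc(Cc3ccccc3)c2)COC12C=CC(=O)C=C2` differs from compound 1 by benzyl in place of hydrogen on an aromatic carbon. Going by the values given here, two measured steps bear on this change. The first, an at least 5.2-fold lower number from compound 1 to compound 2 (0.71 log units; beyond the scatter), shows that a change on the amine nitrogen can move the value out of the limit. The second, a step that the two limits leave unreadable from compound 1 to compound 3, is the closer kin, a carbon substituent on the same aromatic ring, yet its size cannot be read since compound 1 and compound 3 both sit at a limit. With one unreadable step on the aromatic ring and no numbered value for compound 1, the expected step of an at least 1.3-fold lower number from compound 1 to compound 4 (0.12 log units; that floor lies within the scatter) is small or none beyond the scatter. Compound 4 is estimated at 15000 nM, with a range from 4000 nM to 40000 nM.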

Compound 4, half-maximal inhibitory concentration: 6200 nM
Beside the measured number, compound 4's estimate is 2.4-fold (0.38 log units) above it, and the stated range covers the measured number.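

The added benzyl group, meta to a large group, gives an at least 3.2-fold lower number from compound 1 to compound 4 (0.50 log units; beyond the scatter), so a single carbon-linked group on this ring can move the value out of the limit, as the 3,4-dichlorophenyl of compound 2 did. The step to compound 3 cannot be read, which leaves this as the only readable step for a carbon-linked ring substituent among the compounds shown. Only a floor can be given for its size, since compound 1 stands at a limit of the assay: the limit of > 20000 nM in this assay, at which 2 of the 4 values shown sit.

From the compounds shown here alone, what stays open is whether the aromatic ring of the benzyl group is needed at this place, or whether a methyl group or a longer chain such as phenethyl would serve as well. Going by these compounds, a benzyl group at another carbon of the ring is equally open.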